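The source may report more compounds than this note shows. Statements on the series, on what has been measured and on what is new or still open speak of the compounds shown alone.

Measured in a functional assay on A549 cells (Homo sapiens) for inhibition, read by CCK-8 assay, with a stated time of 72 h, tested at 2 uM; a higher number here means more inhibition of growth at the concentration tested, a lower number less inhibition of growth:
- compound 1, `Cc1ccc(SCc2ccc(/C=C/C(=O)Nc3ccccc3N)cc2)cc1`, gives 43.4%
- compound 2, `Nc1ccccc1NC(=O)c1ccc(CSc2nccc(C(F)(F)F)n2)cc1`, gives 75.4%

Among the compounds with values here, of these two numbers, compound 1 holds the lower one; its only neighbour, compound 2, sits higher by a gap that lies beyond the usual scatter of the assay. Compound 2 is built on a different core, so its value says nothing directly about a single change made to compound 1; it marks only the span within which the two measured numbers fall.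

Compound 3, `Nc1ccccc1NC(=O)/C=C/c1ccc(CSc2ccc(F)cc2)cc1`, has not yet been measured. It differs from compound 1 in one place: fluoro in place of methyl on an aromatic carbon. The rest of compound 1 is kept unchanged.

Within the data shown here, no pair of measured compounds differs by this change, nor by any change of a similar kind, so there is no measured guide to how large such a step tends to be here. On the numbers shown, the step from compound 1 to compound 3 is expected to be small, a number 1.6 percentage points higher from compound 1 to compound 3 (within the scatter), and not beyond the scatter in either direction. Compound 3 is therefore estimated at 45% in this assay, with a range from 25% to 65%.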

Compound 3, percent growth inhibition at one concentration: 51.2%
The estimate for compound 3 lay 6.2 percentage points below the measured number, and the stated range covers the measured number.
By their numbers in this assay, from the lowest: compounds 1 and 3 (each within the scatter of the next); then compound 2.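

In this assay, within the data shown here, the exchange of methyl for fluoro on an aromatic carbon, para to a large group, turning the 4-methylphenyl into a 4-fluorophenyl, gives a number 7.8 percentage points higher from compound 1 to compound 3 (within the scatter) and provides the first measured step at this position. On this single pair, the two groups cannot be told apart in this assay, so this position accepts either of them on the core of compound 1 with no difference that stands clear of the usual scatter, although one exchange does not describe the position as a whole. No measurement that could explain the result is at hand.

What the compounds shown leave open is whether a group of another kind at this position, such as an amine, a carboxylic acid or a longer chain, would give a step beyond the scatter, since only methyl and fluoro have been compared there. On these data alone, it also remains open whether the exchange of methyl for fluoro would give a similarly small step on another core or in another cell line.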